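The source may report more compounds than this note shows. Statements on the series, on what has been measured and on what is new or still open speak of the compounds shown alone.

Of the compounds shown here, two carry a measured value so far. Compound 1 `Cc1ccc(N(C(=O)c2ccc([N+](=O)[O-])cc2)C(=S)OCCN2C(=O)c3ccccc3C2=O)cc1` in an ADME assay on MT4 cells (Homo sapiens) for cytotoxicity, read by MTT assay (on this read-out higher numbers stand for lower toxicity in this test and lower numbers for higher toxicity in this test), gives 58000 nM. Compound 2 `O=C1c2ccccc2C(=O)N1CCOC(=S)N(C(=O)c1ccc(F)cc1F)c1ccc(Cl)cc1` in this assay gives 52000 nM, and compound 2 and compound 1 lie within the scatter of each other. Compound 3 `O=C1c2ccccc2C(=O)N1CCOC(=S)N(C(=O)c1ccc([N+](=O)[O-])cc1Cl)c1ccc(Cl)cc1` is not yet measured; how it differs from compound 2: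
2-chloro-4-nitrophenyl in place of 2,4-difluorophenyl on a carbonyl carbon
Going by the values given here, no measured step of that kind exists. In this assay no step beyond the scatter is expected, since compound 1 with 58000 nM and compound 2 with 52000 nM sit close together. The estimate for compound 3 is 50000 nM, with a range from 20000 nM to 110000 nM. This expected value means a step of a 1.0-fold lower number from compound 2 to compound 3 (0.02 log units; within the scatter).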

Compound 3, half-maximal cytotoxic concentration: 19000 nM
The estimate for compound 3 lay 2.6-fold (0.42 log units) above the measured number, and the stated range ends above it.
By their numbers in this assay, from the lowest: compound 3; then compounds 2 and 1 (each within the scatter of the next).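

In this assay the 2-chloro-4-nitrophenyl group in place of 2,4-difluorophenyl on a carbonyl carbon gives a 2.7-fold lower number from compound 2 to compound 3 (0.44 log units; beyond the scatter) and thus shows that a change at this position can move the number beyond the scatter, here towards higher toxicity in this test. Going by these compounds alone, this is the first single-place step, and it is a modest one. Nothing available explains the shift.

On these data alone, whether the chlorine or the nitro group carries the step remains open, since both enter together. Also open, as far as these compounds go, is what a plain phenyl or a 4-aminophenyl group would give on this carbonyl carbon.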